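The compounds below may be only part of what the source reports. "The series", "measured", "known", "first", "only" and "open" are said of these compounds alone.

Measured so far, in a functional assay for activation of Alpha-1B adrenergic receptor (Homo sapiens), read by calcium flux; a lower number here means that less compound is needed, a higher number that more compound is needed for the effect:

Compound 1, `c1cncc(-c2ccccc2OCC2=NCCN2)c1`: 79.4 nM
Compound 2, `c1ccc(-c2ccncn2)c(OCC2=NCCN2)c1`: < 100000 nM, which is a limit of this assay and not a number
Compound 3, `c1c[nH]c(-c2ccccc2OCC2=NCCN2)c1`: 1 nM

Compound 3 stands at the lowest of the two numbers that this assay has given. Its nearest neighbour is compound 1, and the step of a 79-fold lower number from compound 1 to compound 3 (1.90 log units; beyond the scatter) is large and beyond the scatter. Compound 2 gives only a limit (the limit of < 100000 nM in this assay, at which 1 of the 3 values shown sits), so the steps a step that the limit leaves unreadable from compound 1 to compound 2 and a step that the limit leaves unreadable from compound 2 to compound 3 cannot be read in size.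

Compound 4, `c1ccc(-c2ccsc2)c(OCC2=NCCN2)c1`, has not yet been measured. It differs from compound 3 in one place: thiophen-3-yl in place of 1H-pyrrol-2-yl on an aromatic carbon. For the measured compounds named here, no measured step exchanges the 1H-pyrrol-2-yl for a thiophen-3-yl, so the only guide is the large step of a 79-fold lower number from compound 1 to compound 3 (1.90 log units; beyond the scatter), which shows that the ring on this aromatic carbon moves the number strongly. Compound 4 is therefore expected to give a higher number than compound 3, an estimated step of a 20-fold higher number from compound 3 to compound 4 (1.30 log units; beyond the scatter) in this assay. The estimate for compound 4 is 20 nM, with a range from 4 nM to 100 nM.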

Compound 4, half-maximal effective concentration: 15.9 nM
Beside the measured number, compound 4's estimate is 1.3-fold (0.10 log units) above it; measured number inside the range.
By their numbers in this assay, from the lowest: compound 3; then compound 4; then compound 1.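

In this assay, the two five-membered aromatic rings on this aromatic carbon do not behave alike, although each has 5 heavy atoms: a 16-fold higher number from compound 3 to compound 4 (1.20 log units; beyond the scatter). Thiophen-3-yl, which has no hydrogen-bond donor, still gives a lower number than the six-membered pyridin-3-yl, with a 5.0-fold lower number from compound 1 to compound 4 (0.70 log units; beyond the scatter), so a hydrogen-bond donor on the ring is not required for a number lower than that of compound 1. Compound 2 gives only a limit, so its step to compound 4 cannot be read: the limit of < 100000 nM in this assay, at which 1 of the 4 values shown sits.

The exchange changes the hetero atom, the point of attachment and the donor count together, so the compounds shown cannot separate these. On these data alone, it remains open how a thiophen-2-yl, a furan-3-yl or a 1-methyl-1H-pyrrol-2-yl would stand on this carbon.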